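The compounds below may be only part of what the source reports. "The series", "measured", "known", "first", "only" and "open" are said of these compounds alone.

Measured in a functional assay on HT-29 cells (Homo sapiens) for inhibition, read by MTT assay, with a stated time of 48 h; a lower number here means a stronger inhibitor, a higher number a weaker inhibitor:
- Compound 1 `CCSc1nnc(-c2cc(OC)c(OC)c(OC)c2)n1-c1ccc(OC)cc1`: > 60000 nM (a limit, not a number)
- Compound 2 `COc1ccc(-n2c(SCc3ccc(F)cc3)nnc2-c2cc(OC)c(OC)c(OC)c2)cc1`: 50700 nM

Among the measured compounds shown here, compound 2, at 50700 nM, holds the only true number so far in this assay. Compound 3 `COc1ccc(-n2c(SCC(=O)c3ccccc3)nnc2-c2cc(OC)c(OC)c(OC)c2)cc1` differs from it as follows: benzoyl in place of 4-fluorophenyl on a saturated chain carbon bound to a sulfur. For the measured compounds named here, the one measured step at this place, an at least 1.1-fold lower number from compound 1 to compound 2 (0.07 log units; that floor lies within the scatter), also changed the group on a saturated chain carbon bound to a sulfur, so no step beyond the scatter is expected here. Compound 3 may also end at the limit of > 60000 nM in this assay, at which 1 of the 2 values shown sits. The estimated step is a 1.0-fold higher number from compound 2 to compound 3 (0.01 log units; within the scatter). For compound 3 the expected value is 52000 nM, with an estimated range of 25000 nM to 100000 nM.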

Compound 3, half-maximal inhibitory concentration: > 60000 nM
Compound 3: only a limit was reported; the forecaster's own chance of this, stated with the estimate: 45%; middle value at least 1.1-fold (0.06 log units) from the limit.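

Placing benzoyl instead of 4-fluorophenyl at this saturated chain carbon bound to a sulfur gives an at least 1.1-fold higher number from compound 2 to compound 3 (0.07 log units; that floor lies within the scatter), in this assay. This adds a carbonyl at this place without bringing a lower number, though the true size of the step stays hidden, and the step from compound 1 to compound 3 cannot be read, as both values are limits. Most of the series now rests on limits rather than numbers: the limit of > 60000 nM in this assay, at which 2 of the 3 values shown sit.

Still open, on these data alone, is how far compound 3 lies past its limit. Also open, as far as these compounds go, is whether an amine or a carboxylic acid at this place would give a clearly lower number than compound 2.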